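From a 4-bromophenyl to a phenyl group

The source may report more compounds than this note shows. Statements on the series, on what has been measured and on what is new or still open speak of the compounds shown alone.

Of the compounds shown here, three sharing one core have been measured so far: compound 1 `COc1ccc(-c2nnc(SCCCN3CCN(c4nc5ccccc5o4)CC3)o2)cc1`, compound 2 `Cc1ccc(-c2nnc(SCCCN3CCN(c4nc5ccccc5o4)CC3)o2)cc1` and compound 3 `Brc1ccc(-c2nnc(SCCCN3CCN(c4nc5ccccc5o4)CC3)o2)cc1`. They differ only in one group on an aromatic carbon, which is methoxy, methyl or bromo. In a functional assay on HeLa cells (Homo sapiens) for inhibition, read by MTT assay, with a stated time of 72 h (on this read-out lower numbers stand for stronger inhibition and higher numbers for weaker inhibition), compound 1 gives 210000 nM, compound 2 gives 133000 nM and compound 3 gives 187000 nM. Compound 3 thus stands within the scatter of both others, as a 1.1-fold lower number from compound 1 to compound 3 (0.05 log units; within the scatter) and a 1.4-fold higher number from compound 2 to compound 3 (0.15 log units; within the scatter) show.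

The next compound, compound 4 `c1ccc(-c2nnc(SCCCN3CCN(c4nc5ccccc5o4)CC3)o2)cc1`, has hydrogen in place of bromo on an aromatic carbon, para to a large group: hydrogen in place of bromo on an aromatic carbon. The bromo group is simply removed, turning the 4-bromophenyl into phenyl. Going by the values given here, no compound measured so far carries hydrogen at this place, so the guide is the set of swaps already seen. Besides the two steps above, there is a 1.6-fold lower number from compound 1 to compound 2 (0.20 log units; within the scatter), and all three stay within the scatter. No step beyond the scatter is therefore expected in this assay, and the expected change is a 1.1-fold lower number from compound 3 to compound 4 (0.04 log units; within the scatter). Compound 4 is estimated at 170000 nM, with an expected range of 100000 nM to 280000 nM.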

Compound 4, half-maximal inhibitory concentration: 67000 nM
Compound 4: the middle estimate sits 2.5-fold (0.40 log units) above what was measured; measured number outside the range, below it.
By their numbers in this assay, from the lowest: compounds 4, 2, 3 and 1 (each within the scatter of the next, the first and the last beyond it).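

Among the swaps at this position in this assay, only those to hydrogen go beyond the usual scatter: removing bromo, the change from 4-bromophenyl to phenyl, gives one such step (a 2.8-fold lower number from compound 3 to compound 4 (0.45 log units; beyond the scatter)), and replacing methoxy with hydrogen gives another (a 3.1-fold lower number from compound 1 to compound 4 (0.50 log units; beyond the scatter)). Replacing methyl with hydrogen does not clear the scatter (a 2.0-fold lower number from compound 2 to compound 4 (0.30 log units; within the scatter)), so compound 4 is separated from compounds 1 and 3 but not from compound 2, and the position is less indifferent to change than the first three compounds suggested. Nothing measured here explains why the group at this position shifts the number in these steps.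

As far as these compounds go, what an amine, a carboxylic acid or a smaller halogen such as fluoro would give at this place remains open, as does whether any group here could bring the number clearly lower than hydrogen does. From the compounds shown here alone, it is also open whether removing bromo would have a similar effect with a longer chain in the shared core.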